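Moving the bromine around the sulfonyl phenyl ring

The source may hold more compounds than are shown below. What is called first, only, known or untested is meant among the compounds shown, and "the series" means these compounds.

Compound 1 `COc1ccc(-c2cc(=O)c3c(OC)cc(OC)cc3n2C)cc1` carries a methyl on its aromatic nitrogen. In an ADME assay on BJ cells (Homo sapiens) for antiproliferative activity, with a stated time of 72 h (on this read-out higher numbers stand for an effect only at larger amounts of compound and lower numbers for an effect already at smaller amounts), compound 1 gives 68000 nM. Compound 2 `COc1ccc(-c2cc(=O)c3c(OC)cc(OC)cc3n2S(=O)(=O)c2cccc(Br)c2)cc1` bears a (3-bromophenyl)sulfonyl on that nitrogen instead. In this assay compound 2 reaches only a limit of the assay, > 58600 nM. The step that the limit leaves unreadable from compound 1 to compound 2 thus has no readable size, since the limit of > 58600 nM in this assay, at which 1 of the 2 values shown sits, is where one of the two values sits. Compound 3 `COc1ccc(-c2cc(=O)c3c(OC)cc(OC)cc3n2S(=O)(=O)c2ccc(Br)cc2)cc1` differs from compound 2 by 4-bromophenyl in place of 3-bromophenyl on a sulfonyl sulfur. Going by the values given here, no measured step bears on shifting the bromine around the phenyl ring, and the one measured step ends at a limit, so there is no size to carry over. The step that the limit leaves unreadable from compound 2 to compound 3 is expected to stay within the usual scatter. It seems likely that compound 3 will also be reported only as a limit. Compound 3 is estimated at 80000 nM, in a range from 30000 nM to 200000 nM.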

Compound 3, half-maximal effective concentration: > 86200 nM
Compound 3 was reported as a limit (the forecaster's own chance of this, stated with the estimate: 70%); at least 1.0-fold (0.03 log units) between middle value and limit.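

In this assay compound 3, like the other sulfonyl compound, ends at a limit of the assay, so neither bromine placement on the sulfonyl phenyl ring gives a measured number: the limit of > 86200 nM in this assay, at which 1 of the 3 values shown sits. Steps that end at a limit without a readable floor, including the move from 3-bromophenyl to 4-bromophenyl on a sulfonyl sulfur, cannot be read. Going by these compounds, the one readable result is an at least 1.2-fold higher number from compound 1 to compound 3 (0.10 log units; that floor lies within the scatter), so this exchange of the methyl yields only a floor, and the true size of the change stays unknown.

The compounds shown leave open whether any other group on the sulfonyl phenyl ring would give a measured value in this assay. An amine or a carboxylic acid in place of the bromine could test this.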